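Trading a Branched Chain for a Ring on the Amine

The source may report more compounds than this note shows. Statements on the series, on what has been measured and on what is new or still open speak of the compounds shown alone.

Compound 2, `CC(C)CCNc1ncc(-c2cccc(Cl)c2)c(-c2ccccc2)n1`, carries an isopentyl group on a nitrogen attached to the aromatic core. Within the data shown here, in an assay on CHO cells for displacement of a labelled ligand from adenosine receptor A1 (Homo sapiens), read by scintillation counting, with a stated time of 1 h, tested at 1 uM (a higher number here means more inhibition at the concentration tested (going by the name of the read-out), a lower number less inhibition), compound 2 gives 39%, the lower of the two numbers measured so far. Compound 1, `CCCCC(=O)Nc1ncc(-c2cccc(Cl)c2)c(-c2ccccc2)n1`, bears a butylcarbonyl group in the same place and gives 52%, so the step of a number 13 percentage points lower from compound 1 to compound 2 (beyond the scatter) shows that swapping the amide for the plain alkyl chain costs some inhibition.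

Compound 3, `Clc1cccc(-c2cnc(NC3CCCCC3)nc2-c2ccccc2)c1`, replaces the chain with a ring: cyclohexyl in place of isopentyl on a nitrogen on an aromatic ring. Among the measured compounds shown here, the only measured step concerns an amide becoming an alkyl amine, not one alkyl substituent becoming another, so it gives no direct guide; both carbon-only groups are of similar size, and a step within the scatter seems most likely. The expected change is a number 3 percentage points higher from compound 2 to compound 3 (within the scatter), and compound 3 is estimated at 42%, between 25% and 60%.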

Compound 3, a percentage reported as inhibition, at one concentration (the size of the read-out at that concentration, not a potency): 58%
For compound 3 the middle estimate is 16 percentage points below the measured one; the range from low to high includes it.
By their numbers in this assay, from the lowest: compound 2; then compounds 1 and 3 (each within the scatter of the next).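

At this nitrogen, the form of a carbon-only group makes a difference: in this assay, cyclohexyl in place of isopentyl gives a number 19 percentage points higher from compound 2 to compound 3 (beyond the scatter), although neither group has a hydrogen-bond donor or acceptor. The amide is also not required to reach the level of compound 1, since cyclohexyl, which has no carbonyl, gives a number 6 percentage points higher from compound 1 to compound 3 (within the scatter), so the earlier loss on moving to isopentyl does not hold for every group without a carbonyl. Nothing measured here explains why the ring and the chain differ.

As far as these compounds go, it remains open whether this difference needs a ring of exactly this kind, as cyclopentyl or phenyl on the same nitrogen would show. Tetrahydropyranyl, a six-membered ring containing oxygen, would test whether the ring must be carbon only.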